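Ester to acid on the shared core of compound 2

This account rests on a few compounds, and the source may have more. Where it says the series, first, only, none or still open, it means among the compounds named here.

The three measured compounds:
compound 1 `COC(=O)c1cccc(OCc2oc(-c3cccc(OC)c3)nc2C)c1` with 17100 nM
compound 2 `COC(=O)CCc1ccc(OCc2oc(-c3ccccc3OC)nc2C)cc1` with 13600 nM
compound 3 `COC(=O)CCc1ccc(OCc2oc(-c3cccc(OC)c3)nc2C)cc1` with 6700 nM

All three were tested in an assay on cells for antagonist activity at vitamin D3 receptor (Homo sapiens), read by a luciferase reporter; on this read-out lower numbers stand for stronger inhibition and higher numbers for weaker inhibition. Among them compound 2 stands second highest; its nearest neighbour is compound 1, within the scatter, and the largest gap from it is a 2.0-fold lower number from compound 2 to compound 3 (0.31 log units; beyond the scatter).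

The compound to be measured next is compound 4 `COc1ccccc1-c1nc(C)c(COc2ccc(CC(=O)O)cc2)o1`. It differs from compound 2 in one place: carboxy in place of (methoxycarbonyl)methyl on a saturated chain carbon bound to an aromatic carbon. The methoxyphenyl group stays as in compound 2.

Within the data shown here, none of the measured steps bears directly on this change. Among the measured compounds shown here, the only counted step, from compound 2 to compound 3, moves the methoxy group on the phenyl ring and leaves the ester untouched, so it says nothing about replacing an ester by an acid. For the measured compounds named here, with no comparable step to lean on, the expectation for compound 4 is that it stays close to compound 2 and that the change brings no step beyond the scatter in this assay, though the uncertainty is wide in both directions. The estimated value for compound 4 is 13000 nM, with a range from 4000 nM to 40000 nM, which means an expected step of a 1.0-fold lower number from compound 2 to compound 4 (0.02 log units; within the scatter).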

Compound 4, half-maximal inhibitory concentration: > 80000 nM
Compound 4 ended at the assay's limit (the forecaster's own chance of this, stated with the estimate: 15%); middle value at least 6.1-fold (0.78 log units) from the limit.
By their numbers in this assay, from the lowest: compound 3; then compounds 2 and 1 (each within the scatter of the next). At a limit, above all of these: compound 4.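

At this place, on a saturated chain carbon bound to an aromatic carbon, the end of the chain clearly matters in this assay: carboxy in place of (methoxycarbonyl)methyl gives an at least 5.8-fold higher number from compound 2 to compound 4 (0.76 log units; beyond the scatter), towards weaker inhibition. The earlier compounds shown here all kept the ester, and the same difference also reads 2-(methoxycarbonyl)ethyl to carboxymethyl, so the end group and the chain length change together here. Compound 4 is held at a limit of the assay, not a number, and how far its true value lies past that limit cannot be read: the limit of > 80000 nM in this assay, at which 1 of the 4 values shown sits.

The compounds shown leave open whether the weaker inhibition follows the acid or the shorter chain; a 2-carboxyethyl group, with the acid on the longer chain, would help separate the two. Also open, from the compounds shown here alone, is how a primary amide would behave at this place, and whether the acid has the same effect on the 3-methoxyphenyl group of compound 3.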